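Removal of the sulfonyl-bearing side chain from compound 1

The source may report more compounds than this note shows. Statements on the series, on what has been measured and on what is new or still open speak of the compounds shown alone.

Compound 1 `CS(=O)(=O)Cc1cccc(C#Cc2cc(Cl)ccc2OCC(=O)O)c1` stands second highest of the three numbers in hand in an assay on CHO cells for displacement of a labelled ligand from prostaglandin D2 receptor 2 (Homo sapiens), read by scintillation counting; a higher number here means a weaker inhibitor, a lower number a stronger inhibitor. In this assay compound 1 gives 48 nM. Compound 2 `COCCN(C)S(=O)(=O)c1ccc(C)c(C#Cc2cc(Cl)ccc2OCC(=O)O)c1` gives 4.1 nM, a lower number beyond the scatter, while compound 3 `O=C(O)COc1ccccc1C#Cc1ccccc1Cl`, which carries its chlorine on the other ring and bears no further group, gives 747 nM, a higher number beyond the scatter. Together these values show that substitution on the ring attached through the alkyne shifts the read-out over a wide span.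

Compound 4 `O=C(O)COc1ccc(Cl)cc1C#Cc1ccccc1` keeps the shared core of compound 1 and differs from it in one place: hydrogen in place of (methylsulfonyl)methyl on an aromatic carbon. Among the compounds with values here, no measured pair in the set isolates this exact change, so the size of the step is not known from direct precedent. Within the data shown here, with compound 3 at 747 nM as the only unsubstituted comparison, the step from compound 1 to compound 4 is expected to move toward a higher number, beyond the scatter, by roughly an 8.3-fold higher number from compound 1 to compound 4 (0.92 log units; beyond the scatter). Compound 4 is accordingly estimated at 400 nM, with a plausible range from 100 nM to 1500 nM.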

Compound 4, inhibition constant: 108 nM
The estimate for compound 4 lay 3.7-fold (0.57 log units) above the measured number; the measured number falls inside the stated range.
By their numbers in this assay, from the lowest: compound 2; then compound 1; then compound 4; then compound 3.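

In this assay, hydrogen in place of (methylsulfonyl)methyl on this aromatic carbon, meta to a large group, gives a 2.3-fold higher number from compound 1 to compound 4 (0.35 log units; beyond the scatter) and is a modest step, beyond the scatter. Within the data shown here, this is the first single-place measure, and it shows that the (methylsulfonyl)methyl group is not required for binding in this assay, since compound 4 still gives 108 nM without it. No measurement in hand accounts for the size of this step.

The compounds shown leave open whether an amine, a carboxylic acid or a longer chain on the same aromatic carbon would give a lower or a higher number than hydrogen. They also leave open how much of the wide span across the series belongs to this position alone.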